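The compounds below may be only part of what the source reports. "The series", "measured", "known", "first", "only" and "open" are said of these compounds alone.

Compound 3 `Cc1ccc2nc(N3CCCc4ccc(F)cc4C3)cc(NCC(N)=O)c2c1` carries a carbamoylmethyl group on a nitrogen on an aromatic ring; in an ADME assay on HEp-2 cells (Homo sapiens) for cytotoxicity, read by CCK-8 assay, with a stated time of 5 days (a higher number here means that more compound is tolerated, a lower number that less compound is tolerated), compound 3 gives 22000 nM. Compound 1 `Cc1ccc2nc(N3CCCc4ccc(F)cc4C3)cc(NC(C)CN)c2c1` gives 25000 nM in this assay, and compound 2 `Cc1ccc2nc(N3CCCc4ccc(F)cc4C3)cc(NCC3CCCCN3)c2c1` gives 23000 nM; the steps of a 1.1-fold lower number from compound 1 to compound 3 (0.06 log units; within the scatter) and a 1.0-fold lower number from compound 2 to compound 3 (0.02 log units; within the scatter) both stay within the scatter, as does a 1.1-fold lower number from compound 1 to compound 2 (0.04 log units; within the scatter). Compound 4 `Cc1ccc2nc(N3CCCc4ccc(F)cc4C3)cc(NC3(CN)COC3)c2c1` differs from compound 3 by 3-(aminomethyl)oxetan-3-yl in place of carbamoylmethyl on a nitrogen on an aromatic ring. Every measured step exchanges the group on that same nitrogen and none moved the number beyond the scatter, so no step beyond the scatter is expected here either, that is a 1.0-fold higher number from compound 3 to compound 4 (0.02 log units; within the scatter). Compound 4 is therefore estimated at 23000 nM, with a range from 12000 nM to 45000 nM.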

Compound 4, half-maximal cytotoxic concentration: 86000 nM
For compound 4 the middle estimate is 3.7-fold (0.57 log units) below the measured one; measured number above the stated range.
By their numbers in this assay, from the lowest: compounds 3, 2 and 1 (each within the scatter of the next); then compound 4.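

In this assay, the group on a nitrogen on an aromatic ring can move the number beyond the scatter after all: 3-(aminomethyl)oxetan-3-yl gives a 3.9-fold higher number from compound 3 to compound 4 (0.59 log units; beyond the scatter), a 3.7-fold higher number from compound 2 to compound 4 (0.57 log units; beyond the scatter) and a 3.4-fold higher number from compound 1 to compound 4 (0.54 log units; beyond the scatter). The aminomethyl part alone does not mark the change, since compound 1 also carries it and stays within the scatter of compound 2 and compound 3. Nothing available here explains the rise.

The compounds shown leave open whether it belongs to the four-membered ring or to its oxygen. A cyclobutane ring carrying the same aminomethyl group would separate the two.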